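A few compounds are considered here, and "the series" means these few. Any claim that something is new, unique, unknown or untested is made for them only; others in the source may bear on it.

Measured so far in a functional assay on aorta (Rattus norvegicus, strain Wistar) for inhibition, with a stated time of 60 min; on this read-out higher numbers stand for an effect only at larger amounts of compound and lower numbers for an effect already at smaller amounts:

compound 1, `CCOc1ccccc1-c1nc2cc([N+](=O)[O-])ccc2[nH]1`: 3710 nM
compound 2, `CCOc1ccccc1-c1nc2cc(C(F)(F)F)ccc2[nH]1`: 549000 nM
compound 3, `COc1ccc(-c2nc3cc([N+](=O)[O-])ccc3[nH]2)cc1OC`: 2500 nM

Compound 2 stands at the highest number of the three, far from compound 1 and further still from compound 3, so on this read-out it needs the largest amount to act. Compound 4, `O=[N+]([O-])c1ccccc1-c1nc2cc(C(F)(F)F)ccc2[nH]1`, differs from compound 2 in one place: nitro in place of ethoxy on an aromatic carbon. Within the data shown here, the only measured single step, a 150-fold higher number from compound 1 to compound 2 (2.17 log units; beyond the scatter), changes a different group on the shared core and so does not speak to swapping ethoxy for nitro; compounds 1 and 3 differ in more than one place. Among the measured compounds shown here, with no step bearing on this change, compound 4 is expected near compound 2, with an estimated shift of a 1.4-fold lower number from compound 2 to compound 4 (0.14 log units; within the scatter) and wide uncertainty. The estimate for compound 4 is 400000 nM, within 80000 nM to 2000000 nM.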

Compound 4, half-maximal effective concentration: 3180 nM
The estimate for compound 4 lay 130-fold (2.10 log units) above the measured number; the whole stated range lies above it.
By their numbers in this assay, from the lowest: compounds 3, 4 and 1 (each within the scatter of the next); then compound 2.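

Swapping ethoxy for nitro on this aromatic carbon, ortho to a large group, gives in this assay a large change (a 170-fold lower number from compound 2 to compound 4 (2.24 log units; beyond the scatter)), so this place, which no earlier single step touched, strongly affects the amount of compound needed. Ethoxy and nitro have the same count of heavy atoms, so that count does not separate them. No measurement shown here explains the change. Going by these compounds, whether an amine or a carboxylic acid in this place would act like nitro remains open, as does whether the same swap gives a similar change with nitro instead of trifluoromethyl on the shared core.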